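Cytotoxicity in the series: step to compound 3

The compounds below may be only part of what the source reports. "The series", "measured", "known", "first", "only" and "open" are said of these compounds alone.

Compound 1 `Cc1ccc(-c2cnc(NC(=O)c3ccc(F)cc3)n2C)cc1`: 60000 nM
Compound 2 `COc1ccc(-c2cnc(NC(=O)c3ccc(F)cc3)n2C)cc1`: >= 50000 nM (a limit)

In a toxicity assay on THP-1 cells (Homo sapiens) for inhibition (a lower number here means that less compound is tolerated, a higher number that more compound is tolerated), compound 1 gives 60000 nM. Compound 2 gives >= 50000 nM, which is a limit of the assay and not a number. This is the limit of >= 50000 nM in this assay, at which 1 of the 2 values shown sits.

Compound 3 `Cn1c(-c2cccc(C#N)c2)cnc1NC(=O)c1ccc(F)cc1` follows from compound 2 by one change on the shared core: 3-cyanophenyl in place of 4-methoxyphenyl on an aromatic carbon. In words, 3-cyanophenyl stands in place of 4-methoxyphenyl on an aromatic carbon.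

For the measured compounds named here, only one measured step bears on this change, a step that the limit leaves unreadable from compound 1 to compound 2. It gives no size, and it concerns a different exchange on the same aromatic ring. Going by the values given here, no measured step therefore shows how replacing the whole 4-methoxyphenyl group acts in this assay. Among the compounds with values here, the expectation rests mainly on compound 1 at 60000 nM, the only true number available. No change beyond the scatter is expected in either direction, and the expected step is a number no higher from compound 2 to compound 3 (the limit leaves the size open). For compound 3 the estimated value is 50000 nM, with an expected range of 20000 nM to 100000 nM.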

Compound 3, half-maximal cytotoxic concentration: > 100000 nM
Compound 3 was reported as a limit; the forecaster's own chance of this, stated with the estimate: 55%; middle value at least 2.0-fold (0.30 log units) from the limit.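

Compound 3 is reported only as a limit of the assay, not as a number: the limit of > 100000 nM in this assay, at which 1 of the 3 values shown sits.

In this assay, for the compounds shown here, the one readable comparison is an at least 1.6-fold higher number from compound 1 to compound 3 (0.22 log units; that floor lies within the scatter). Its floor does not establish a real rise, but it does show that exchanging the whole aryl group on this aromatic carbon for 3-cyanophenyl brings no fall in the number, a point the earlier pair, holding only 4-methylphenyl and 4-methoxyphenyl here, could not settle. The steps from compound 1 to compound 2 and from compound 2 to compound 3 cannot be read.

From the compounds shown here alone, the true size of the difference stays open, as does whether the nitrile or its ring position matters, since 3-cyanophenyl differs from 4-methylphenyl in both the substituent and where it sits. Also open, going by these compounds, is whether tolerance in this assay persists with an aminomethyl group or a carboxylic acid on this phenyl ring, or with a saturated ring such as cyclohexyl in its place.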